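A few compounds are considered here, and "the series" means these few. Any claim that something is new, unique, unknown or untested is made for them only; others in the source may bear on it.

Of the compounds shown here, three that share the same imide core have been tested in an ADME assay on Vero cells (Chlorocebus sabaeus) for cytotoxicity; on this read-out higher numbers stand for weaker inhibition and lower numbers for stronger inhibition. Compound 1, `C[C@@H](c1ccccc1)N1C(=O)c2nccnc2C1=O`, carries a branched benzylic substituent on the imide nitrogen; in this assay compound 1 gives 85000 nM. Compound 2, `COc1ccc(CN2C(=O)c3cccnc3C2=O)cc1`, has a methoxybenzyl group on the nitrogen and a different arrangement of nitrogen within the fused ring. For compound 2 this assay reports only a limit, > 100000 nM, and no number. Compound 3, `O=C1c2nccnc2C(=O)N1c1ccccc1`, carries a plain phenyl on the imide nitrogen; in this assay compound 3 gives 71000 nM. For the measured compounds named here, the numbers for compound 3 and compound 1 lie within the usual scatter of each other, so neither can be said to be the more cytotoxic; the only other value shown is the limit noted in the limit of > 100000 nM in this assay, at which 1 of the 3 values shown sits.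

Compound 4, `CCCCCc1ccc(N2C(=O)c3nccnc3C2=O)cc1`, is the next compound to be measured in this assay. It differs from compound 3 by a single change: pentyl in place of hydrogen on an aromatic carbon. Going by the values given here, no measured pair in this set isolates such a change, so there is nothing to calibrate it against. The expectation is a modest move toward stronger inhibition, estimated as a 2.0-fold lower number from compound 3 to compound 4 (0.31 log units; beyond the scatter), though a result within the scatter of compound 3 is also plausible. For compound 4 in this assay the estimate is 35000 nM, with a likely range from 10000 nM to 100000 nM.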

Compound 4, half-maximal inhibitory concentration: 16000 nM
Compound 4: middle estimate off by 2.2-fold (0.34 log units), on the high side; measured number inside the range.
By their numbers in this assay, from the lowest: compound 4; then compounds 3 and 1 (each within the scatter of the next). At a limit, above all of these: compound 2.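

In this assay, pentyl in place of hydrogen on an aromatic carbon, para to a large group, gives a 4.4-fold lower number from compound 3 to compound 4 (0.65 log units; beyond the scatter), and this step lies beyond the usual scatter. For the compounds shown here, it is the first comparison in this set in which only one place changes, so it shows what the earlier compounds could not: the read-out responds to a substitution at this position of the phenyl ring on the imide nitrogen, and a pentyl chain there goes with stronger inhibition of the Vero cells. Nothing measured here accounts for this shift, so the step records what happens at this position and gives no reason for it.

Going by these compounds, with a single chain at a single position, it remains open whether the shift follows chain length, so a methyl group or a longer chain such as octyl at the same carbon would be informative, as would an amine or a carboxylic acid, which would show whether a chain of carbon atoms is needed at all. On these data alone, it is also open whether a pentyl group would produce a similar step on the other nitrogen substituents, such as the branched benzylic group of compound 1.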